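Swapping 2-chlorophenyl for 4-methylphenyl

The source may report more compounds than this note shows. Statements on the series, on what has been measured and on what is new or still open speak of the compounds shown alone.

In a physicochemical assay for solubility, read by HPLC, in simulated intestinal fluid, with a stated time of 16 h, at pH 6.5 (a higher number here means a more soluble compound, a lower number a less soluble compound), compound 3 `CNC(=O)c1cc(C(=O)N[C@H]2CC[C@H](O)CC2)c([C@@H](C)c2ccccc2Cl)o1` reads > 1000 ug/mL as a limit of the assay, not a number. On the same core, compound 1 `CNC(=O)c1cc(C(=O)N[C@H]2CC[C@H](O)CC2)c([C@@H](C)c2cccc(Cl)c2)o1` gives 408 ug/mL and compound 2 `CNC(=O)c1cc(C(=O)N[C@H]2CC[C@H](O)CC2)c([C@@H](C)c2cccc(OC)c2)o1` gives 868 ug/mL as measured values.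

Compound 4 `CNC(=O)c1cc(C(=O)N[C@H]2CC[C@H](O)CC2)c([C@@H](C)c2ccc(C)cc2)o1` is not yet measured. It differs by 4-methylphenyl in place of 2-chlorophenyl on a saturated chain carbon bound to an aromatic carbon and a saturated chain carbon in that 4-methylphenyl stands in place of 2-chlorophenyl on a saturated chain carbon bound to an aromatic carbon and a saturated chain carbon.

Among the compounds with values here, three measured steps bear on this change. The step of an at least 2.4-fold higher number from compound 1 to compound 3 (0.38 log units; beyond the scatter) replaces 3-chlorophenyl with 2-chlorophenyl, and the step of a 2.1-fold higher number from compound 1 to compound 2 (0.33 log units; beyond the scatter) puts methoxy in place of chloro, both of them modest. The step of an at least 1.1-fold higher number from compound 2 to compound 3 (0.06 log units; that floor lies within the scatter) adds little. None of them involves 4-methylphenyl, so the guide is loose.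

Read backwards, the step of an at least 2.4-fold higher number from compound 1 to compound 3 (0.38 log units; beyond the scatter) suggests a modest move to a lower number. The expected change is an at least 1.8-fold lower number from compound 3 to compound 4 (0.25 log units; that floor lies within the scatter) and it is only an estimate. Compound 4 is estimated at 550 ug/mL with 220 ug/mL to 1000 ug/mL as its expected range.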

Compound 4, solubility: > 1000 ug/mL
Compound 4 ended at the assay's limit (the forecaster's own chance of this, stated with the estimate: 15%); middle value at least 1.8-fold (0.25 log units) away from the limit.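

Compound 4 sits at a limit of this assay, not at a number, so 4-methylphenyl, which carries neither chlorine nor methoxy, reaches the same ceiling at this position as 2-chlorophenyl. Against the 3-chlorophenyl group the change gives an at least 2.4-fold higher number from compound 1 to compound 4 (0.38 log units; beyond the scatter), while against the 3-methoxyphenyl group it gives an at least 1.1-fold higher number from compound 2 to compound 4 (0.06 log units; that floor lies within the scatter). The step between compound 3 and compound 4 cannot be read, and no order can be given for these two compounds: the limit of > 1000 ug/mL in this assay, at which 2 of the 4 values shown sit.

Going by these compounds, how far compound 3 and compound 4 lie past that limit stays open. Also open, on these data alone, is whether an amine or a carboxylic acid in place of the methyl of 4-methylphenyl would keep a reading at the limit or bring it down to a measurable number.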